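The source may report more compounds than this note shows. Statements on the series, on what has been measured and on what is new or still open speak of the compounds shown alone.

Working notes on the series. For the measured compounds named here, in a functional assay on the whole organism for inhibition, with Rattus norvegicus as the target (a lower number here means that less compound is needed, a higher number that more compound is needed for the effect), compound 2 `CC(Cc1ccc(Cl)cc1)(Oc1ccc(C2CCSc3ccccc32)cc1)C(=O)O` gives 10 mg/kg, the higher of the two numbers so far, while compound 1 `CC(Cc1ccc(Cl)cc1)(Oc1ccc(Cc2ccccc2)cc1)C(=O)O` gives 1 mg/kg. The next compound to be read is compound 3 `CC(Cc1ccc(Cl)cc1)(Oc1ccc(Br)cc1)C(=O)O`, and the change to it is one bromine atom in place of a group of 10 heavy atoms (9 carbon, 1 sulfur; one six-membered non-aromatic ring with 1 hetero atom, one six-membered aromatic ring of carbon only), on an aromatic carbon. Going by the values given here, only one measured step bears on this place: a 10-fold higher number from compound 1 to compound 2 (1.00 log units; beyond the scatter), a modest step beyond the scatter between two groups that both contain a ring. Among the compounds with values here, no measured compound yet carries a single atom there, so the read-across is weak. Compound 1, with the smaller of those two groups, stands at 1 mg/kg, so a moderate move toward lower numbers is expected in this assay. The estimated step is a 3.3-fold lower number from compound 2 to compound 3 (0.52 log units; beyond the scatter). For compound 3 the estimate is 3 mg/kg, with an expected range of 0.8 mg/kg to 12 mg/kg.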

Compound 3, dose for half-maximal effect: < 1 mg/kg
Compound 3 ended at the assay's limit; the forecaster's own chance of this, stated with the estimate: 5%; at least 3.0-fold (0.47 log units) between middle value and limit.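

Until now this position had carried only groups containing a ring, so a single atom there was untested. On this aromatic carbon in this assay, bromo in place of the group with the sulfur-bearing non-aromatic ring gives an at least 10-fold lower number from compound 2 to compound 3 (1.00 log units; beyond the scatter), so no ring is needed at this position for the effect. Compound 3 is read as a limit of the assay, not as a number: the limit of < 1 mg/kg in this assay, at which 1 of the 3 values shown sits.

Bromo in place of benzyl on the same aromatic carbon gives a number no higher from compound 1 to compound 3 (the limit leaves the size open), so the size of this step cannot be read. Also open, from the compounds shown here alone, is whether a different small group on the same aromatic carbon, such as fluoro, methoxy or an amine, would give a readable number in this assay and so place bromo on a scale.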